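Methylsulfonyl Added to a Benzamide Pair Stuck at the Limit

The source may hold more compounds than are shown below. What is called first, only, known or untested is meant among the compounds shown, and "the series" means these compounds.

Compound 1, `O=C(Nc1ccc(Cl)c(-c2nnc3c(Cl)cccn23)c1)c1ccccc1`, was tested in a functional assay on T47D cells (Homo sapiens) for antiproliferative activity, read by MTT assay, with a stated time of 72 h; on this read-out higher numbers stand for weaker inhibition and lower numbers for stronger inhibition. In this assay compound 1 gives only a limit of the assay, > 100000 nM, and not a number. Compound 2, `O=C(Nc1ccc(Cl)c(-c2nnc3c(Cl)cccn23)c1)c1ccc(Cl)cc1Cl`, carries a 2,4-dichlorophenyl in place of phenyl on a carbonyl carbon. In this assay compound 2 likewise stands at a limit, > 100000 nM. The step that the two limits leave unreadable from compound 1 to compound 2 therefore cannot be read, since (the limit of > 100000 nM in this assay, at which 2 of the 2 values shown sit).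

Compound 3, `CS(=O)(=O)c1cccc(C(=O)Nc2ccc(Cl)c(-c3nnc4c(Cl)cccn34)c2)c1`, differs from compound 1 by methylsulfonyl in place of hydrogen on an aromatic carbon. Going by the values given here, the one measured step offers no size to lean on, as both of its values sit at the limit. Compound 3 is therefore expected to land near that same limit, with the step that the limit leaves unreadable from compound 1 to compound 3 expected to stay small. The estimate for compound 3 in this assay is 150000 nM, with a range from 40000 nM to 500000 nM.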

Compound 3, half-maximal inhibitory concentration: > 100000 nM
Compound 3 gave a limit, no number; the forecaster's own chance of this, stated with the estimate: 80%; the middle value does not contradict the limit.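

No step can be read between compound 1, compound 2 and compound 3, since all three stand at a limit of the assay and not at a number: the limit of > 100000 nM in this assay, at which 3 of the 3 values shown sit. From the compounds shown here alone, whether any group on that phenyl can give a readable number in this assay remains open.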